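The source may report more compounds than this note shows. Statements on the series, on what has been measured and on what is new or still open speak of the compounds shown alone.

Compound 1, `CC(=O)Oc1ccc(-c2cncn2C2CCN(C(=O)c3ccc(Cl)c(C(F)(F)F)c3)CC2)cc1`, was tested in an assay on HEK293 cells for antagonist activity at P2X purinoceptor 7 (Homo sapiens), read by fluorescence, with a stated time of 2 h; on this read-out higher numbers stand for weaker inhibition and lower numbers for stronger inhibition. In this assay compound 1 gives only a limit, > 10000 nM. Among the compounds with values here, compound 2, `O=C(c1ccc(Cl)c(C(F)(F)F)c1)N1CCC(n2cncc2-c2ccc(OS(=O)(=O)c3cccc([N+](=O)[O-])c3)cc2)CC1`, carries a (3-nitrophenyl)sulfonyl in place of the acetyl on the ring oxygen, and in this assay compound 2 gives 249 nM, which is the only plain number so far. The change amounts to an at least 40-fold lower number from compound 1 to compound 2 (1.60 log units; beyond the scatter), and its size can only be given as a bound because of the limit of > 10000 nM in this assay, at which 1 of the 2 values shown sits. Compound 3, `CCN(CC)C(=O)c1cccc(S(=O)(=O)Oc2ccc(-c3cncn3C3CCN(C(=O)c4ccc(Cl)c(C(F)(F)F)c4)CC3)cc2)c1`, keeps the sulfonyl link and differs from compound 2 only in diethylcarbamoyl in place of nitro on an aromatic carbon. Within the data shown here, the single measured step swapped the whole group on the ring oxygen; no measured step exchanges one substituent on the sulfonyl-bearing ring for another, so the large step from compound 1 to compound 2 offers no direct guide here. Among the measured compounds shown here, with no comparable precedent, the expected step is a 1.2-fold higher number from compound 2 to compound 3 (0.08 log units; within the scatter), within the usual scatter. Compound 3 is therefore estimated at 300 nM, in a range from 80 nM to 1200 nM.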

Compound 3, half-maximal inhibitory concentration: 202 nM
Beside the measured number, compound 3's estimate is 1.5-fold (0.17 log units) above it, within the range that was stated.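

In this assay, replacing nitro with diethylcarbamoyl is a small change in the result: the step is a 1.2-fold lower number from compound 2 to compound 3 (0.09 log units; within the scatter), so the two compounds cannot be told apart on this read-out. Within the data shown here, this is the first measured change on the ring carried by the sulfonyl link, and it shows that at this place, on an aromatic carbon meta to a large group, the nitro is not required to keep inhibition at the level of compound 2, since a group of 7 heavy atoms with 1 hydrogen-bond acceptor reads the same as one of 3 heavy atoms with 2 hydrogen-bond acceptors. The data shown offer no explanation of why these two different groups read alike.

The compounds shown leave open whether this tolerance extends to other kinds of group at the same place, such as a primary amine, a carboxylic acid or a longer alkyl chain. They also leave open whether the ethyl groups on the amide nitrogen matter, which a comparison with an unsubstituted carboxamide at this place could test.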